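Trifluoromethoxy in place of tert-butyl on the aryl urea

The compounds below may be only part of what the source reports. "The series", "measured", "known", "first", "only" and "open" are said of these compounds alone.

Compound 3 `Cc1cc(NC(=O)Nc2ccc(C(C)(C)C)cc2)c2ccccc2n1` is one of three ureas on a shared core tested in an ADME assay on Raji cells (Homo sapiens) for cytotoxicity, with a stated time of 72 h; on this read-out higher numbers stand for an effect only at larger amounts of compound and lower numbers for an effect already at smaller amounts. For compound 3 the value > 25000 nM is only a limit of the assay. Compound 1 `CSc1ccc(NC(=O)Nc2cc(C)nc3ccccc23)cc1` likewise gives only a limit, > 25000 nM, in this assay. For the measured compounds named here, compound 2 `Cc1cc(NC(=O)Nc2ccc(SC(F)(F)F)cc2)c2ccccc2n1` is the sole one with a number, 10000 nM in this assay. Two of the three values sit at a limit (the limit of > 25000 nM in this assay, at which 2 of the 3 values shown sit). Compound 4 `Cc1cc(NC(=O)Nc2ccc(OC(F)(F)F)cc2)c2ccccc2n1` carries trifluoromethoxy in place of tert-butyl on an aromatic carbon. The step of an at least 2.5-fold higher number from compound 2 to compound 3 (0.39 log units; beyond the scatter) bears on this, and an at least 2.5-fold lower number from compound 1 to compound 2 (0.39 log units; beyond the scatter) shows trifluoromethyl reaching a number where methyl did not. Compound 4 is therefore expected to show a modest step of an at least 1.6-fold lower number from compound 3 to compound 4 (0.22 log units; that floor lies within the scatter) toward a lower number, though a limit remains possible. Compound 4 is estimated at 15000 nM, in the range 6000 nM to 40000 nM.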

Compound 4, half-maximal effective concentration: 10000 nM
Compound 4: middle estimate off by 1.5-fold (0.18 log units), on the high side; the measured number falls inside the stated range.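

Trifluoromethoxy in place of tert-butyl brings an at least 2.5-fold lower number from compound 3 to compound 4 (0.39 log units; beyond the scatter), and in place of methylsulfanyl it brings an at least 2.5-fold lower number from compound 1 to compound 4 (0.39 log units; beyond the scatter), so a second fluorinated group at this position gives a number. Trifluoromethoxy in place of (trifluoromethyl)sulfanyl brings no change at the digits printed from compound 2 to compound 4 (within the scatter), so these two groups are not told apart on this read-out. Both steps that start from a limit give floors only: the limit of > 25000 nM in this assay, at which 2 of the 4 values shown sit.

Open, going by these compounds, is whether the fluorines or the linking atom matter, which methoxy or a trifluoromethyl set directly on the ring would separate. An amine or a carboxylic acid at this position also remains untested in the compounds shown.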